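This account rests on a few compounds, and the source may have more. Where it says the series, first, only, none or still open, it means among the compounds named here.

Compound 2 `CCCCOC(=O)CNC(=O)[C@H](CSc1ccc([N+](=O)[O-])cc1[N+](=O)[O-])NC(=O)CC[C@H](NC(=O)OCc1ccccc1)C(=O)OCCCC` gives 95.2 uM in a toxicity assay on KB cells (Homo sapiens) for cytotoxicity, read by fluorescence, with a stated time of 3 days (on this read-out lower numbers stand for an effect already at smaller amounts and higher numbers for an effect only at larger amounts of compound), which is the highest of the two numbers in this small series; its nearest neighbour is compound 3 `CCCCOC(=O)CNC(=O)[C@H](CSc1ccc([N+](=O)[O-])cc1[N+](=O)[O-])NC(=O)CC[C@H](NC(=O)CCc1c[nH]c2ccccc12)C(=O)OCCCC`, which gives 26 uM. Compound 1 `CCCCOC(=O)CNC(=O)[C@H](CSc1ccc([N+](=O)[O-])cc1[N+](=O)[O-])NC(=O)CC[C@H](NC(=O)c1ccccc1)C(=O)OCCCC` reaches only a limit of > 300 uM in this assay, not a number. Compound 4 `CCCCOC(=O)CNC(=O)[C@H](CSc1ccc([N+](=O)[O-])cc1[N+](=O)[O-])NC(=O)CC[C@H](NC(=O)CCc1ccccc1)C(=O)OCCCC` has not yet been measured. It differs from compound 2 in one place: phenethyl in place of benzyloxy on a carbonyl carbon. Among the compounds with values here, three measured steps bear on this change. Replacing phenyl with benzyloxy gave an at least 3.1-fold lower number from compound 1 to compound 2 (0.49 log units; beyond the scatter), replacing phenyl with 2-(1H-indol-3-yl)ethyl gave an at least 11-fold lower number from compound 1 to compound 3 (1.06 log units; beyond the scatter), and replacing benzyloxy with 2-(1H-indol-3-yl)ethyl gave a 3.7-fold lower number from compound 2 to compound 3 (0.56 log units; beyond the scatter). Phenethyl shares the ethyl link of 2-(1H-indol-3-yl)ethyl but carries only the six-membered carbon ring also present in benzyloxy. A smaller step in the same direction is therefore expected for compound 4, a 1.9-fold lower number from compound 2 to compound 4 (0.28 log units; within the scatter). Compound 4 is estimated at 50 uM, with a range from 20 uM to 150 uM.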

Compound 4, concentration for half-maximal effect: > 300 uM
Compound 4: a limit, no number; the forecaster's own chance of this, stated with the estimate: 5%; at least 6.0-fold (0.77 log units) between middle value and limit.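

In this assay, exchanging benzyloxy for phenethyl on the same carbonyl carbon keeps the six-membered aromatic ring and the count of heavy atoms, yet it gives an at least 3.1-fold higher number from compound 2 to compound 4 (0.49 log units; beyond the scatter), so that ring and atom count do not alone set the read-out in this pair. Keeping the chain and exchanging 1H-indol-3-yl for phenyl gives an at least 11-fold higher number from compound 3 to compound 4 (1.06 log units; beyond the scatter), which ties the lower number of compound 3 to the 1H-indol-3-yl group, not to the ethyl link alone. The step between compound 1 and compound 4 cannot be read, as both values are limits: the limit of > 300 uM in this assay, at which 2 of the 4 values shown sit.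

Going by these compounds, how far compound 4 lies beyond its limit remains open. Also open, on these data alone, is how a hydroxyl on the phenyl ring of compound 4, or a longer chain carrying 1H-indol-3-yl, would read in this assay.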